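The source may hold more compounds than are shown below. What is called first, only, known or untested is meant among the compounds shown, and "the series" means these compounds.

Compound 2 `CS/C(=N\C(=O)c1cc(-c2ccccc2)nc2ccccc12)NC(=O)c1cc(-c2ccccc2)nc2ccccc12` and compound 1 `O=C(/N=C(/NC(=O)c1cc(-c2ccccc2)nc2ccccc12)[Se]Cc1ccccc1)c1cc(-c2ccccc2)nc2ccccc12` share one core. In a functional assay on PC-3 cells (Homo sapiens) for cytotoxicity, read by MTT assay, with a stated time of 72 h (a lower number here means a stronger inhibitor of growth, a higher number a weaker inhibitor of growth), compound 2 reaches only the limit of the measurement, > 100000 nM. In this assay compound 1 gives 97100 nM. The change between them is a group of 8 heavy atoms (7 carbon, 1 selenium; one six-membered aromatic ring of carbon only) in place of a group of 2 heavy atoms (1 carbon, 1 sulfur; no ring), on a carbon with a double bond to nitrogen, and it made an at least 1.0-fold lower number from compound 2 to compound 1 (0.01 log units; that floor lies within the scatter); that this step rests on the limit of > 100000 nM in this assay, at which 2 of the 3 values shown sit, keeps it a floor rather than a measured difference.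

Compound 3 `CS/C(=N\C(=O)c1cnc2ccccc2c1)NC(=O)c1cnc2ccccc2c1` carries a different core, and the difference between the two cores is not broken down here. In this assay compound 3 likewise sits at the limit of the measurement, > 100000 nM.

Compound 4 `O=C(/N=C(/NC(=O)c1cnc2ccccc2c1)[Se]Cc1ccccc1)c1cnc2ccccc2c1` has not yet been measured. It differs from compound 3 by a group of 8 heavy atoms (7 carbon, 1 selenium; one six-membered aromatic ring of carbon only) in place of a group of 2 heavy atoms (1 carbon, 1 sulfur; no ring), on a carbon with a double bond to nitrogen, the same change as that from compound 2 to compound 1, made on the same kind of carbon. Because the earlier change gave an at least 1.0-fold lower number from compound 2 to compound 1 (0.01 log units; that floor lies within the scatter), with compound 1 barely inside the measurable range, the step is expected to be a step that the limit leaves unreadable from compound 3 to compound 4. Compound 4 is therefore expected to give about 120000 nM, somewhere from 50000 nM to 300000 nM, and a further limit rather than a number is thought likely.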

Compound 4, concentration for total growth inhibition: > 100000 nM
Compound 4: a limit, no number; the forecaster's own chance of this, stated with the estimate: 60%; the middle value is on the limit's open side.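

In this assay compound 4 gives > 100000 nM, which is a limit and not a number. With compound 3 also at a limit, no step from compound 3 to compound 4 can be read: the limit of > 100000 nM in this assay, at which 3 of the 4 values shown sit.

The compounds shown leave open whether replacing methylsulfanyl with the group in compound 4 changes growth inhibition on this core at all.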